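Cytotoxic aryl-substituted fused aminonitriles on Ehrlich cells

The compounds below may be only part of what the source reports. "The series", "measured", "known", "first", "only" and "open" are said of these compounds alone.

Measured compounds:
compound 1 `COc1cc(N2C(N)=C(C#N)C(c3ccccc3O)C3=C2CC(C)(C)CC3=O)cc(OC)c1OC`: 2%
compound 2 `COc1cc(N2C(N)=C(C#N)C(c3ccc(OC)c4ccccc34)C3=C2CC(C)(C)CC3=O)cc(OC)c1OC`: 40%
compound 3 `COc1cc(N2C(N)=C(C#N)C(c3cccc([N+](=O)[O-])c3)C3=C2CC(C)(C)CC3=O)cc(OC)c1OC`: 30%

Compound 3 stands second highest of the three numbers in a functional assay on Ehrlich cells (Mus musculus) for cytotoxicity, tested at 50 ug/mL; on this read-out higher numbers stand for a stronger effect at the one concentration tested and lower numbers for a weaker effect; its nearest neighbour is compound 2, which lies within the scatter of it, and compound 1 lies well below it.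

Compound 4 `COc1ccccc1C1C(C#N)=C(N)N(c2cc(OC)c(OC)c(OC)c2)C2=C1C(=O)CC(C)(C)C2` is not yet measured in this assay. It differs from compound 3 by 2-methoxyphenyl in place of 3-nitrophenyl on a saturated ring carbon.

For the measured compounds named here, no measured step exchanges these two groups directly. The step of a number 28 percentage points higher from compound 1 to compound 3 (beyond the scatter) is the closest comparison: there a 3-nitrophenyl group replaced a 2-hydroxyphenyl group, and the present change removes the 3-nitrophenyl again in favour of another single-ring aryl with one substituent. The step of a number 38 percentage points higher from compound 1 to compound 2 (beyond the scatter) shows that the low number of compound 1 is not shared by every aryl at this carbon, so the reverse direction is not assured. The expected step of a number 18 percentage points lower from compound 3 to compound 4 (beyond the scatter) is therefore downward, of modest size, with wide uncertainty.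

Compound 4 is estimated at 12%, within a range from 0% to 35%.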

Compound 4, a percentage reported as activity, at one concentration (the size of the read-out at that concentration, not a potency): 70%
Estimate against measurement, compound 4: 58 percentage points below; measured number outside the range, above it.
By their numbers in this assay, from the lowest: compound 1; then compounds 3 and 2 (each within the scatter of the next); then compound 4.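

In this assay, for the compounds shown here, the aryl group on this saturated ring carbon decides far more than the earlier compounds suggested: a number 40 percentage points higher from compound 3 to compound 4 (beyond the scatter), and a number 30 percentage points higher from compound 2 to compound 4 (beyond the scatter), so neither 3-nitrophenyl nor 4-methoxynaphthalen-1-yl marks the upper end for this position. The sharpest contrast comes with the smallest change, methyl in place of hydrogen on the oxygen on the aromatic ring, where a number 68 percentage points higher from compound 1 to compound 4 (beyond the scatter), so the low number of compound 1 does not extend to 2-methoxyphenyl. Nothing available accounts for this difference between the hydroxy and methoxy compounds.

As far as these compounds go, whether an ethoxy or an amino group in place of the methoxy group of 2-methoxyphenyl would keep the high number remains open. From the compounds shown here alone, each number shows a stronger or weaker effect at a single concentration, so how the effects compare at other concentrations also remains open.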